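Benzoyl ester variation on a flavonolignan scaffold

The source may report more compounds than this note shows. Statements on the series, on what has been measured and on what is new or still open speak of the compounds shown alone.

Compound 1 `COc1cc(C2Oc3cc([C@H]4Oc5cc(O)cc(O)c5C(=O)[C@@H]4O)ccc3OC2COC(=O)c2cc(OC)c(OC)c(OC)c2)ccc1O`: in a functional assay, read by spectrophotometry, with a stated time of 30 min (a lower number here means that less compound is needed, a higher number that more compound is needed for the effect), compound 1 gives 94800 nM.
Compound 2 `COc1cc(C2Oc3cc([C@H]4Oc5cc(O)cc(O)c5C(=O)[C@@H]4O)ccc3OC2COC(=O)c2ccccc2)ccc1O`: in this assay compound 2 gives 105000 nM.
Compound 3 `COc1cc(C2Oc3cc([C@H]4Oc5cc(O)cc(O)c5C(=O)[C@@H]4O)ccc3OC2COC(=O)c2cc(N)cc([N+](=O)[O-])c2)ccc1O`: for compound 3 this assay reports only a limit, > 300000 nM.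

Compound 3 therefore has no number of its own; it sits at the limit of > 300000 nM in this assay, at which 1 of the 3 values shown sits, and so it stands apart from compound 1 and compound 2, which both return measured values. The step to compound 4 `COc1cc(C2Oc3cc([C@H]4Oc5cc(O)cc(O)c5C(=O)[C@@H]4O)ccc3OC2COC(=O)c2ccc(OC)c(OC)c2)ccc1O` reads (3,4-dimethoxyphenyl in place of 3-amino-5-nitrophenyl on a carbonyl carbon). Among the compounds with values here, two measured steps bear on it: an at least 3.1-fold higher number from compound 1 to compound 3 (0.50 log units; beyond the scatter) and an at least 2.8-fold higher number from compound 2 to compound 3 (0.45 log units; beyond the scatter), both at least modest and both running toward the limit. The change in compound 4 undoes the 3-amino-5-nitrophenyl group and returns a methoxy-bearing phenyl, closer to compound 1, while a 1.1-fold higher number from compound 1 to compound 2 (0.04 log units; within the scatter) shows that phenyl and 3,4,5-trimethoxyphenyl sit within the scatter of each other. Compound 4 is accordingly expected to move back out of the limit, a step estimated as an at least 3.0-fold lower number from compound 3 to compound 4 (0.47 log units; beyond the scatter). For compound 4 the estimate in this assay is 100000 nM, ranging from 50000 nM to 250000 nM.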

Compound 4, half-maximal effective concentration: 77000 nM
The estimate for compound 4 lay 1.3-fold (0.11 log units) above the measured number; measured number inside the range.
By their numbers in this assay, from the lowest: compounds 4, 1 and 2 (each within the scatter of the next). At a limit, above all of these: compound 3.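

At the carbonyl carbon, 3,4-dimethoxyphenyl in place of 3-amino-5-nitrophenyl restores a measured number in this assay, with an at least 3.8-fold lower number from compound 3 to compound 4 (0.59 log units; beyond the scatter). The new group cannot be told apart from the other two, with a 1.4-fold lower number from compound 2 to compound 4 (0.13 log units; within the scatter) and a 1.2-fold lower number from compound 1 to compound 4 (0.09 log units; within the scatter), so phenyl, 3,4-dimethoxyphenyl and 3,4,5-trimethoxyphenyl all lie within the scatter of one another here, and removing one methoxy from compound 1 has no readable effect. Compound 3 alone remains apart, its entry a limit and not a number: the limit of > 300000 nM in this assay, at which 1 of the 4 values shown sits.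

The compounds shown leave open whether the amino group, the nitro group or the two together go with the shift seen in compound 3. They also leave open how a ring carrying only an amine, only a nitro group or a carboxylic acid would read at this carbonyl carbon.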